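A few compounds are considered here, and "the series" means these few. Any claim that something is new, unique, unknown or untested is made for them only; others in the source may bear on it.

Among the compounds with values here, in a physicochemical assay for solubility, at pH 6.5 (a higher number here means a more soluble compound, a lower number a less soluble compound), compound 2 `C[S+]([O-])c1cccc(-c2ccc3ncc(-c4ccc(S(C)(=O)=O)cc4)n3n2)c1` gives 157000 nM, the only outright number among the two results so far. Compound 1 `CS(=O)(=O)c1ccc(-c2cnc3ccc(-c4cncc(C(F)(F)F)c4)nn23)cc1` sits at the limit of < 5000 nM in this assay, at which 1 of the 2 values shown sits, a limit of the assay rather than a number, reported as < 5000 nM. Compound 3 `CS(=O)(=O)c1ccc(-c2cnc3ccc(-c4cncc(N)c4)nn23)cc1` is not yet measured; it differs from compound 2 by a group of 7 heavy atoms (5 carbon, 2 nitrogen; one six-membered aromatic ring with 1 hetero atom) in place of a group of 9 heavy atoms (7 carbon, 1 oxygen, 1 sulfur; one six-membered aromatic ring of carbon only), on an aromatic carbon. Within the data shown here, no measured pair shows this change, so the expectation rests on these two compounds alone. The expected step is a 5.2-fold lower number from compound 2 to compound 3 (0.72 log units; beyond the scatter), toward lower solubility and probably beyond the usual scatter. Compound 3 is estimated at 30000 nM, within a range from 5000 nM to 150000 nM.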

Compound 3, solubility: 15000 nM
Estimate against measurement, compound 3: 2.0-fold (0.30 log units) above; the measured number falls inside the stated range.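

Keeping the rest of compound 1 and putting amino in place of trifluoromethyl gives an at least 3.0-fold higher number from compound 1 to compound 3 (0.47 log units; beyond the scatter) in this assay, so a single group on this ring already moves the read-out. The size of that step is open-ended, as compound 1 carries a limit and not a number: the limit of < 5000 nM in this assay, at which 1 of the 3 values shown sits. Replacing the whole group on this aromatic carbon of the shared core reaches further, with a 10-fold lower number from compound 2 to compound 3 (1.02 log units; beyond the scatter). From the compounds shown here alone, how a hydroxyl or a dimethylamino group in place of amino would read in this assay stays open.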